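A few compounds are considered here, and "the series" means these few. Any claim that something is new, unique, unknown or untested is made for them only; others in the source may bear on it.

Two compounds carry a dichlorophenyl group on a small heterocyclic core. Compound 1 `CS(=O)(=O)Nc1nc(-c2ccc(Cl)c(Cl)c2)cs1` in a physicochemical assay for solubility, measured as kinetic solubility, with a stated time of 1 h, at pH 7.4 (on this read-out lower numbers stand for lower solubility and higher numbers for higher solubility), gives 429000 nM, while compound 2 `CC(=O)NC1=NN(c2ccc(Cl)c(Cl)c2)CC1` gives 31000 nM, the lowest of the two numbers, and the gap between these two lies beyond the usual scatter. Compound 3 `O=C(NC1=NN(c2ccc(Cl)c(Cl)c2)CC1)c1cncnc1` has not yet been measured. It differs from compound 2 by one change: pyrimidin-5-yl in place of methyl on a carbonyl carbon. Among the measured compounds shown here, with no comparable pair measured, the step is expected to be a modest decrease, perhaps only just beyond the scatter, giving a 2.1-fold lower number from compound 2 to compound 3 (0.32 log units; beyond the scatter). Compound 3 is therefore estimated at 15000 nM, within a range from 4000 nM to 60000 nM.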

Compound 3, solubility: 8000 nM
Beside the measured number, compound 3's estimate is 1.9-fold (0.27 log units) above it, and the stated range covers the measured number.
By their numbers in this assay, from the lowest: compound 3; then compound 2; then compound 1.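

In this assay the change from methyl to pyrimidin-5-yl on a carbonyl carbon gives a 3.9-fold lower number from compound 2 to compound 3 (0.59 log units; beyond the scatter). Among the compounds shown here, this is the first comparison here in which only one place differs, and it shows that the group at this position can move the read-out beyond the usual scatter. Nothing measured here explains why the number falls.

Still open, from the compounds shown here alone, is whether the drop comes with rings in general or with this ring in particular. A phenyl ring, a longer alkyl chain or an amine at the same place could help separate these possibilities.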